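Compound 3 and its diisopropylamino group, still unmeasured

The source may hold more compounds than are shown below. What is called first, only, known or untested is meant among the compounds shown, and "the series" means these compounds.

Compound 1 `Cc1cc(=O)c2c(O)c(CN3CCC(N4CCCCC4)CC3)c(O)c([C@H]3CCN(C)C[C@H]3O)c2o1`: 25%
Compound 2 `Cc1cc(=O)c2c(O)c(CN3CCCC3CO)c(O)c([C@H]3CCN(C)C[C@H]3O)c2o1`: 22%

Both compounds were tested in a functional assay on MCF7 cells (Homo sapiens) for inhibition, read by MTT assay, with a stated time of 48 h, tested at 10 uM; on this read-out lower numbers stand for less inhibition of growth and higher numbers for more inhibition of growth at the one concentration tested. In this assay, within the data shown here, compound 2 gives 22% and compound 1 gives 25%, two values within the usual scatter of each other, so compound 2 stands level with the only other number available.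

Compound 3 `Cc1cc(=O)c2c(O)c(CN(C(C)C)C(C)C)c(O)c([C@H]3CCN(C)C[C@H]3O)c2o1` has not yet been measured. It differs from compound 2 as follows: diisopropylamino in place of 2-(hydroxymethyl)pyrrolidin-1-yl on a saturated chain carbon bound to an aromatic carbon. In words, diisopropylamino stands in place of 2-(hydroxymethyl)pyrrolidin-1-yl on a saturated chain carbon bound to an aromatic carbon.

Among the measured compounds shown here, no step between measured compounds is available as a guide. The data offer only the closeness of compound 1 at 25% and compound 2 at 22%, so no change beyond the scatter is expected, in either direction. The expected step is a number 1 percentage points higher from compound 2 to compound 3 (within the scatter). For compound 3 the estimated value is 23%, with an expected range from 8% to 38%.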

Compound 3, percent growth inhibition at one concentration: 33%
Compound 3: middle estimate off by 10 percentage points, on the low side; the measured number falls inside the stated range.
By their numbers in this assay, from the lowest: compounds 2, 1 and 3 (each within the scatter of the next, the first and the last beyond it).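

In this assay, the place on a saturated chain carbon bound to an aromatic carbon now yields its first readable step: diisopropylamino in place of 2-(hydroxymethyl)pyrrolidin-1-yl gives a number 11 percentage points higher from compound 2 to compound 3 (beyond the scatter). The read-out therefore responds to a change at this place, even though the incoming and outgoing groups have the same number of heavy atoms. The change removes the ring and the hydrogen-bond donor together, so the step cannot be assigned to either one, and nothing measured here bears on why it arises.

A plain pyrrolidin-1-yl group at this place would separate the effect of the hydroxymethyl from that of the ring, while a diethylamino group would test the size of the open-chain amine. On these data alone, how far the step holds at other concentrations also remains open, as each compound was read at a single one.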